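A few compounds are considered here, and "the series" means these few. Any claim that something is new, unique, unknown or untested is made for them only; others in the source may bear on it.

Only a little is known so far about this shared core in a functional assay on HL-60 cells (Homo sapiens), with a stated time of 48 h; on this read-out lower numbers stand for an effect already at smaller amounts and higher numbers for an effect only at larger amounts of compound. Compound 1 `C/C(=C\c1ccccc1C(=O)O)c1ccc2c(c1)C(C)(C)CCC2(C)C` gives > 100000 nM, and this is a limit of the assay and not a number. Among the compounds with values here, compound 2 `CC1(C)CCC(C)(C)c2cc(/C=C/c3ccc(N)cc3)ccc21` gives 38000 nM, the only actual number so far, so there is no second number to compare it with.

Compound 3 `CC1(C)CCC(C)(C)c2cc(/C=C/c3cccc(N)c3)ccc21` has not yet been measured. It has the same atoms as compound 2, joined differently: 3-aminophenyl in place of 4-aminophenyl on a double-bonded chain carbon bound to a double-bonded chain carbon. In words, 3-aminophenyl stands in place of 4-aminophenyl on a double-bonded chain carbon bound to a double-bonded chain carbon.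

Within the data shown here, no pair of measured compounds differs in just one place, so the data show nothing directly about what such a swap does. Among the measured compounds shown here, the only starting point is compound 2 at 38000 nM, and from there no change beyond the usual scatter is expected in this assay, in either direction. The expected step of a 1.1-fold higher number from compound 2 to compound 3 (0.02 log units; within the scatter) is therefore small, though this is a loosely supported guess. For compound 3 the estimated value is 40000 nM, with an expected range from 14000 nM to 100000 nM.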

Compound 3, concentration for half-maximal activity: 40000 nM
The estimate for compound 3 equals the measured number at the digits printed, and the stated range covers the measured number.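

In this assay, 3-aminophenyl in place of 4-aminophenyl on a double-bonded chain carbon bound to a double-bonded chain carbon gives a 1.1-fold higher number from compound 2 to compound 3 (0.02 log units; within the scatter). Within the data shown here, at this place, then, the two aminophenyl groups cannot be told apart on this read-out, and this is the first direct reading of a single change, as the earlier values offered no pair differing in one place. Compound 2 and compound 3 both give actual numbers, whereas compound 1 stands at a limit of the assay: the limit of > 100000 nM in this assay, at which 1 of the 3 values shown sits.

Still open, on these data alone, is whether the same lack of a readable difference would hold for other groups on this ring, such as a hydroxyl group, a methoxy group or an amide in place of the amine. Compound 1 differs from compound 2 in more than one place, so the compounds shown cannot say which of those differences separates a limit in this assay from an actual number.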